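Pyridin-4-yl in place of 4-fluorophenyl: working notes

A few compounds are considered here, and "the series" means these few. Any claim that something is new, unique, unknown or untested is made for them only; others in the source may bear on it.

Compound 1 `CC(C)(C)n1cc2c(n1)C(=O)CC1(CCN(C(=O)c3cc(-c4ccccc4)nc4ccccc34)CC1)O2`: 2110 nM
Compound 2 `CC(C)(C)n1cc2c(n1)C(=O)CC1(CCN(C(=O)c3cc(-c4ccc(F)cc4)nc4ccccc34)CC1)O2`: 2930 nM

Within the data shown here, in a functional assay on HepG2 cells (Homo sapiens) for inhibition, read by MTT assay, with a stated time of 72 h (a higher number here means a weaker inhibitor, a lower number a stronger inhibitor), compound 2 gives 2930 nM, within the scatter of compound 1, the only other compound measured. Compound 3 `CC(C)(C)n1cc2c(n1)C(=O)CC1(CCN(C(=O)c3cc(-c4ccncc4)nc4ccccc34)CC1)O2` carries pyridin-4-yl in place of 4-fluorophenyl on an aromatic carbon. Among the measured compounds shown here, the one measured step bearing on this, a 1.4-fold higher number from compound 1 to compound 2 (0.14 log units; within the scatter), alters the same aryl group and stays within the scatter. For the measured compounds named here, no measured step puts a nitrogen into that ring, so the expectation is uncertain, but no step beyond the scatter is expected. The expected step is a 1.1-fold lower number from compound 2 to compound 3 (0.05 log units; within the scatter). Compound 3 is estimated at 2600 nM, with an expected range of 1200 nM to 6000 nM.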

Compound 3, half-maximal inhibitory concentration: 380 nM
Estimate against measurement, compound 3: 6.8-fold (0.84 log units) above; measured number below the stated range.
By their numbers in this assay, from the lowest: compound 3; then compounds 1 and 2 (each within the scatter of the next).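

In this assay this aryl position turns out to be responsive: pyridin-4-yl gives a 7.7-fold lower number from compound 2 to compound 3 (0.89 log units; beyond the scatter) and a 5.6-fold lower number from compound 1 to compound 3 (0.74 log units; beyond the scatter) while the change from phenyl to 4-fluorophenyl stayed within the scatter. The difference therefore appears only with the ring that carries a hetero atom, and both carbon-only rings lie on the weaker side of it. Nothing available explains this step.

Whether the ring nitrogen must stand where it does in pyridin-4-yl remains open, as pyridin-3-yl and pyrimidin-5-yl are not among the compounds shown. Also open, going by these compounds, is whether the same step would hold with an amine or a carboxylic acid on this ring.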